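The compounds below may be only part of what the source reports. "The series", "measured", "known", "first", "only" and "open" are said of these compounds alone.

In a functional assay on A549 cells (Homo sapiens) for antiproliferative activity, read by CCK-8 assay, with a stated time of 72 h (on this read-out higher numbers stand for weaker inhibition of growth and lower numbers for stronger inhibition of growth), compound 1 `CCC1C(=O)N(C)c2cnc(-n3ccc4cc(C(=O)NC(C)C)ccc43)nc2N1c1ccn(C)n1` gives 22000 nM while compound 2 `CCCCNC(=O)c1ccc2c(ccn2-c2ncc3c(n2)N(c2ccn(C)n2)C(CC)C(=O)N3C)c1` gives 37300 nM and compound 3 `CCNC(=O)c1ccc2c(ccn2-c2ncc3c(n2)N(c2ccn(C)n2)C(CC)C(=O)N3C)c1` gives 21700 nM as its value. These three values lie within the scatter of one another, so compound 3 stands level with the other two. The next compound, compound 4 `CCC1C(=O)N(C)c2cnc(-n3ccc4cc(C(=O)NCC(C)C)ccc43)nc2N1c1ccn(C)n1`, differs from compound 3 by isopropyl in place of methyl on a saturated chain carbon bound to an amide-type nitrogen in one place: isopropyl in place of methyl on a saturated chain carbon bound to an amide-type nitrogen, which turns ethylcarbamoyl into isobutylcarbamoyl. For the measured compounds named here, two measured steps touch this same amide group. One is a 1.0-fold lower number from compound 1 to compound 3 (0.01 log units; within the scatter) and the other is a 1.7-fold lower number from compound 2 to compound 3 (0.24 log units; within the scatter) and neither leaves the scatter. Isobutyl is closest by name to the butyl of compound 2, so a slight rise in the number is expected, but no step beyond the scatter. Going by the values given here, the expected move is a 1.4-fold higher number from compound 3 to compound 4 (0.14 log units; within the scatter) as an estimate resting on only three compounds. For compound 4 the estimated value in this assay is 30000 nM with an expected range from 17000 nM to 50000 nM at its upper end.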

Compound 4, concentration for 50% growth inhibition: 19200 nM
Compound 4: middle estimate off by 1.6-fold (0.19 log units), on the high side, within the range that was stated.
By their numbers in this assay, from the lowest: compounds 4, 3, 1 and 2 (each within the scatter of the next).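

In this assay, isobutyl in place of ethyl on the amide nitrogen gives a 1.1-fold lower number from compound 3 to compound 4 (0.05 log units; within the scatter), and the two other steps to the new compound, a 1.9-fold lower number from compound 2 to compound 4 (0.29 log units; within the scatter) and a 1.1-fold lower number from compound 1 to compound 4 (0.06 log units; within the scatter), also stay inside the scatter. This position has now carried ethyl, isopropyl, butyl and isobutyl, and the branched isobutyl chain stands level with all three, so among these four compounds a change in this alkyl chain produces no readable step. No supporting measurement is available to explain why these values stay level.

All four groups shown are plain alkyl chains, so the effect of a terminal amine or carboxylic acid on the chain remains open. Also open, as far as these compounds go, is whether a phenyl ring on the amide nitrogen would move the number beyond the scatter.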